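The source may report more compounds than this note shows. Statements on the series, on what has been measured and on what is new or still open speak of the compounds shown alone.

Measured in a functional assay (muscle tissue) with Cavia porcellus as the target; a higher number here means that more compound is needed for the effect, a lower number that less compound is needed:
- compound 1 `COC(=O)C1=C(C)N=C(C)/C(=C(\O)OC)C1c1ccccc1F`: 42.7 nM
- compound 2 `COC(=O)C1=C(C)N=C(C)/C(=C(\O)OC)C1c1ccc(Cl)cc1Cl`: 640 nM

For the measured compounds named here, of the two, compound 2 has the higher number, and compound 1 is its only neighbour. Compound 3 `COC(=O)C1=C(C)N=C(C)/C(=C(\O)OC)C1c1cccc(F)c1` has not yet been measured in this assay. It carries 3-fluorophenyl in place of 2,4-dichlorophenyl on a saturated ring carbon.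

Going by the values given here, only one measured step bears on this change. It is a 15-fold higher number from compound 1 to compound 2 (1.18 log units; beyond the scatter), a large step that replaced 2-fluorophenyl with 2,4-dichlorophenyl on the same ring carbon. Compound 3 also gives up 2,4-dichlorophenyl, so a move back towards compound 1 is expected, meaning a lower number than that of compound 2. Among the compounds with values here, the full distance is not expected to be recovered, since 3-fluorophenyl is not the 2-fluorophenyl of compound 1, and no measurement yet compares these two groups. With a single step to draw on, the expectation remains loose. The estimated step is a 4.9-fold lower number from compound 2 to compound 3 (0.69 log units; beyond the scatter). For compound 3 the expected value is 130 nM, with an estimated range from 30 nM to 550 nM.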

Compound 3, half-maximal effective concentration: 20.9 nM
Beside the measured number, compound 3's estimate is 6.2-fold (0.79 log units) above it, outside the stated range (below it).
By their numbers in this assay, from the lowest: compound 3; then compound 1; then compound 2.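

In this assay, putting 3-fluorophenyl in place of 2,4-dichlorophenyl on the saturated ring carbon gave a 31-fold lower number from compound 2 to compound 3 (1.49 log units; beyond the scatter) and so showed that this position spans a wider range than compound 1 and compound 2 alone had revealed. The two fluorophenyl groups also proved not to be interchangeable: 3-fluorophenyl in place of 2-fluorophenyl gave a 2.0-fold lower number from compound 1 to compound 3 (0.31 log units; beyond the scatter) as a modest step, and this leaves compound 3 with the lowest number of the three. Nothing at hand accounts for either step.

The three compounds leave open how the high number of compound 2 arises, as they change the halogen, the number of halogens and their places on the phenyl ring together, and a 2-chlorophenyl, 3-chlorophenyl or 4-chlorophenyl group would be needed to separate these changes. They also do not show whether the order seen here would hold for a 4-fluorophenyl or 3-nitrophenyl group at this ring carbon, or with an ethoxycarbonyl group in place of the methoxycarbonyl group.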